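This account rests on a few compounds, and the source may have more. Where it says the series, first, only, none or still open, it means among the compounds named here.

In a functional assay on CCRF-CEM cells (Homo sapiens) for inhibition (on this read-out higher numbers stand for weaker inhibition and lower numbers for stronger inhibition), compound 2 `CS(=O)(=O)OC[C@H]1OC(n2cc(F)c(=O)[nH]c2=O)[C@H](O)[C@@H]1O` gives 660 nM as the lower of two numbers, while compound 1 `Cc1ccc(S(=O)(=O)OC[C@H]2OC(n3cc(F)c(=O)[nH]c3=O)[C@H](O)[C@@H]2O)cc1` gives 1800 nM as the higher. Compound 3 `[N-]=[N+]=NC[C@H]1OC(n2cc(F)c(=O)[nH]c2=O)[C@H](O)[C@@H]1O` has azido in place of (methylsulfonyl)oxy on a saturated chain carbon bound to a saturated ring carbon, a change counted as azido in place of (methylsulfonyl)oxy on a saturated chain carbon bound to a saturated ring carbon and not yet measured. Among the compounds with values here, the one measured step that bears on this is a 2.7-fold lower number from compound 1 to compound 2 (0.44 log units; beyond the scatter) and it was modest. It only exchanged the group on the sulfonyl sulfur, so it is a loose guide for a change that removes the sulfonyl group altogether. In this assay the expected shift is a 3.0-fold higher number from compound 2 to compound 3 (0.48 log units; beyond the scatter) as a modest move toward weaker inhibition, with the direction uncertain. For compound 3 the estimate is 2000 nM with 300 nM to 15000 nM as its expected range.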

Compound 3, half-maximal inhibitory concentration: 350000 nM
Estimate against measurement, compound 3: 180-fold (2.24 log units) below; the measured number lies above the stated range.
By their numbers in this assay, from the lowest: compound 2; then compound 1; then compound 3.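

In this assay, azido in place of (methylsulfonyl)oxy on a saturated chain carbon bound to a saturated ring carbon gives a 530-fold higher number from compound 2 to compound 3 (2.72 log units; beyond the scatter). This large step shows that inhibition depends far more on replacing the whole (methylsulfonyl)oxy group than on the modest exchange at the sulfonyl sulfur seen earlier. No available evidence explains the jump. The compounds shown cannot tell whether the loss follows from azido entering or from (methylsulfonyl)oxy leaving. An amine or a hydroxyl group at this place could help separate those two readings.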